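Cytotoxicity notes on a benzyl-imidazole aniline series

The source may hold more compounds than are shown below. What is called first, only, known or untested is meant among the compounds shown, and "the series" means these compounds.

The shared core is represented by compound 1 `COC(=O)c1ccc(NCc2cncn2Cc2ccccc2C(C)(C)C)cc1-c1ccccc1`; in a toxicity assay on NIH3T3 cells (Mus musculus) for cytotoxicity, read by resazurin assay (on this read-out higher numbers stand for an effect only at larger amounts of compound and lower numbers for an effect already at smaller amounts), compound 1 is recorded as "not determined" (no result reported), so compound 1 stands on no number here. The only figure in this assay belongs to compound 2 `CCc1ccc(Cn2cncc2CNc2ccc(-c3nc4ccccc4s3)c(-c3ccccc3)c2)cc1`: in this assay compound 2 reaches only the limit > 1000 nM, a limit of the assay and not a number. That is the whole of the evidence, as the limit of > 1000 nM in this assay, at which 1 of the 2 values shown sits, states.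

The step to be followed leads from compound 1 to compound 3 `COC(=O)c1ccc(NCc2cncn2Cc2cccc([N+](=O)[O-])c2)cc1-c1ccccc1`, the change being (3-nitrophenyl in place of 2-(tert-butyl)phenyl on a saturated chain carbon bound to an aromatic nitrogen). Going by the values given here, no measured step exists between the two, and no direction or size can be taken from the numbers, so no shift beyond the usual scatter is assumed.

For compound 3 the value in this assay is expected near 3000 nM, with a range estimated from 1000 nM to 30000 nM, and a result stated only as a limit is expected to be the most likely outcome.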

Compound 3, half-maximal effective concentration: > 10000 nM
Compound 3: only a limit was reported; the forecaster's own chance of this, stated with the estimate: 75%; middle value at least 3.3-fold (0.52 log units) from the limit.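

No step can be read from compound 1 to compound 3 in this assay. Compound 3 gives > 10000 nM, a limit and not a number. The compounds shown leave open what 3-nitrobenzyl in place of 2-(tert-butyl)benzyl does in this assay, and at what concentration compound 3 takes effect.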